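Swapping the benzyl ring of compound 2 for a thiophene

This account rests on a few compounds, and the source may have more. Where it says the series, first, only, none or still open, it means among the compounds named here.

Compound 2 `O=C(COCc1ccccc1)N1CCN(c2ccc(Cl)cc2Cl)CC1` is the starting point. In a functional assay on HEK293 cells for positive allosteric modulation of metabotropic glutamate receptor 5 (Homo sapiens), read by FLIPR and calcium flux (a higher number here means that more compound is needed for the effect, a lower number that less compound is needed), compound 2 gives 1000 nM, the lowest of the two numbers recorded. Its closest neighbour is compound 1 `O=C(COCc1ccccc1)N1CCN(c2ccccc2Cl)CC1`, which in this assay gives 1100 nM; the step of a 1.1-fold lower number from compound 1 to compound 2 (0.04 log units; within the scatter) is chloro in place of hydrogen on an aromatic carbon. Compound 3 `O=C(COCc1ccccc1)N1CCN(c2ccncc2)CC1` gives only a limit, > 25000 nM, in this assay. One of the three values sits at the limit of > 25000 nM in this assay, at which 1 of the 3 values shown sits. The steps of an at least 22-fold higher number from compound 1 to compound 3 (1.35 log units; beyond the scatter) and an at least 25-fold higher number from compound 2 to compound 3 (1.39 log units; beyond the scatter) both replace a chlorinated ring with pyridin-4-yl on an amine nitrogen in a ring.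

Compound 4 `O=C(COCc1cccs1)N1CCN(c2ccc(Cl)cc2Cl)CC1` differs from compound 2 at the other end of the molecule: thiophen-2-yl in place of phenyl on a saturated chain carbon bound to an oxygen on a saturated carbon. Among the compounds with values here, none of the measured steps touches this part of the shared core, so no direct comparison exists. As far as these compounds go, since every change at this position is untested, the expected step of a 1.2-fold higher number from compound 2 to compound 4 (0.08 log units; within the scatter) is one within the scatter, in no particular direction. Compound 4 is therefore estimated to give 1200 nM in this assay, with a likely range from 400 nM to 4000 nM.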

Compound 4, half-maximal effective concentration: > 310 nM
Compound 4 was reported as a limit; the forecaster's own chance of this, stated with the estimate: 10%; the middle value does not contradict the limit.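

In this assay compound 4 gives only a limit of > 310 nM and so the step from compound 2 to compound 4 cannot be read. The compounds shown leave open whether thiophen-2-yl in place of phenyl on this saturated chain carbon raises, lowers or leaves unchanged the number seen for compound 2.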